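This account rests on a few compounds, and the source may have more. Where it says the series, first, only, none or still open, it means among the compounds named here.

Measured so far:
- compound 1, `O=[N+]([O-])c1ccc(-c2csc(N3N=C(c4ccc(Cl)s4)CC3c3ccc(F)cc3)n2)cc1`. In an ADME assay on NIH3T3 cells (Mus musculus) for cytotoxicity, read by XTT assay, with a stated time of 24 h (a lower number here means a stronger inhibitor, a higher number a weaker inhibitor), compound 1 gives > 500 ug/mL, which is a limit of the assay rather than a number.
- compound 2, `COc1ccc(-c2csc(N3N=C(c4ccc(Cl)s4)CC3c3ccc(F)cc3)n2)cc1`. In this assay compound 2 gives 103 ug/mL.

Within the data shown here, compound 2 therefore holds the only plain number in this assay; the other value shown is a limit. Among the measured compounds shown here, the single measured step, an at least 4.8-fold lower number from compound 1 to compound 2 (0.68 log units; beyond the scatter), starts from that limit, (the limit of > 500 ug/mL in this assay, at which 1 of the 2 values shown sits), so its true size is known only as a lower bound.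

Compound 3, `N#Cc1ccc(-c2csc(N3N=C(c4ccc(Cl)s4)CC3c3ccc(F)cc3)n2)cc1`, differs from compound 2 in one place: cyano in place of methoxy on an aromatic carbon. For the measured compounds named here, no measured step involves a cyano group, so the nitro-to-methoxy step is the only guide, and it shows that swapping the group at this position can move the number by at least a modest amount. A modest rise in the number, a 2.1-fold higher number from compound 2 to compound 3 (0.33 log units; beyond the scatter), is expected for compound 3, with a real chance that only a limit is reported. The estimate for compound 3 in this assay is 220 ug/mL, with a range from 80 ug/mL to 500 ug/mL.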

Compound 3, half-maximal inhibitory concentration: > 500 ug/mL
Compound 3 gave a limit, no number; the forecaster's own chance of this, stated with the estimate: 30%; middle value at least 2.2-fold (0.35 log units) from the limit.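

In this assay, among these compounds, methoxy is now the only group at this position, on the six-membered aromatic ring para to a large group, that gives a plain number, as nitro and cyano both end at a limit. The change from methoxy to cyano gives an at least 4.8-fold higher number from compound 2 to compound 3 (0.68 log units; beyond the scatter), and since the two groups have the same count of heavy atoms and of hydrogen-bond acceptors, those counts alone do not separate them. The step between compound 1 and compound 3 cannot be read, so nitro and cyano cannot be ranked, with most values now sitting at one limit: the limit of > 500 ug/mL in this assay, at which 2 of the 3 values shown sit.

On these data alone, the true numbers of compound 1 and compound 3 remain open. Also open, as far as these compounds go, is whether an amine or a longer chain such as ethoxy on this carbon would give a plain number, and how it would compare with methoxy.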